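Sulfanyl side-chain variation on the shared core

This account rests on a few compounds, and the source may have more. Where it says the series, first, only, none or still open, it means among the compounds named here.

Measured so far:
Compound 1 `CC(C(=O)NCc1ccc(C(C)(C)C)nc1OC1CCCCC1)c1ccc(NS(C)(=O)=O)c(F)c1` gives 2.5 nM in an assay on cells for antagonist activity at transient receptor potential cation channel subfamily V member 1 (Homo sapiens), read by FLIPR and calcium flux, with a stated time of 6 min; on this read-out higher numbers stand for weaker inhibition and lower numbers for stronger inhibition.
Compound 2 `CCCCCCSc1nc(C(C)(C)C)ccc1CNC(=O)C(C)c1ccc(NS(C)(=O)=O)c(F)c1` gives 1.5 nM in this assay.

Compound 2 has the smaller of the two numbers, but the step of a 1.7-fold lower number from compound 1 to compound 2 (0.22 log units; within the scatter) lies within the scatter, so no order between the two can be claimed. Compound 3 `CC(C(=O)NCc1ccc(C(C)(C)C)nc1SCc1ccccc1Cl)c1ccc(NS(C)(=O)=O)c(F)c1` has not yet been measured. It differs from compound 2 by 2-chlorophenyl in place of pentyl on a saturated chain carbon bound to a sulfur. Going by the values given here, the only measured step on record, a 1.7-fold lower number from compound 1 to compound 2 (0.22 log units; within the scatter), changed the substituent on the same aromatic carbon without leaving the scatter; it does not test an aromatic ring in place of a chain on the sulfur side. With nothing beyond the scatter seen, the expectation for compound 3 in this assay is a step of a 1.2-fold higher number from compound 2 to compound 3 (0.08 log units; within the scatter), that is none beyond the scatter. Compound 3 is therefore estimated at 1.8 nM, with a range from 0.5 nM to 6 nM.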

Compound 3, inhibition constant: 3.8 nM
Beside the measured number, compound 3's estimate is 2.1-fold (0.32 log units) below it, within the range that was stated.
By their numbers in this assay, from the lowest: compounds 2, 1 and 3 (each within the scatter of the next, the first and the last beyond it).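

In this assay, 2-chlorophenyl in place of pentyl on a saturated chain carbon bound to a sulfur gives a 2.5-fold higher number from compound 2 to compound 3 (0.40 log units; beyond the scatter), the first step shown that leaves the scatter, so the read-out does respond to a change on this sulfur side chain, though only modestly. Swapping the cyclohexyloxy group for the (2-chlorobenzyl)sulfanyl group gives a 1.5-fold higher number from compound 1 to compound 3 (0.18 log units; within the scatter), so that pair cannot be ordered, and the aromatic side chain remains level with the cyclohexyloxy group within the scatter. Nothing on record accounts for the step from hexyl to 2-chlorobenzyl.

As far as these compounds go, it remains open whether that step goes with the aromatic ring or with its chlorine, a question a plain benzyl on the sulfur would separate. Also open, from the compounds shown here alone, is how a chain longer than hexyl, or one ending in an amine or a carboxylic acid, would read at this position in this assay.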